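The source may hold more compounds than are shown below. What is called first, only, known or untested is meant among the compounds shown, and "the series" means these compounds.

Among the compounds with values here, only two compounds have been measured so far in a physicochemical assay for lipophilicity, read by HPLC, at pH 7.5; on this read-out lower numbers stand for lower lipophilicity and higher numbers for higher lipophilicity. Compound 1 `CCOc1ccccc1-c1ccc(-c2nc3cnccc3cc2C#N)cc1` gives 3.8, the higher of the two numbers, while compound 2 `N#Cc1c(-c2ccc(Br)cc2)nc2cnccc2c1NCC(N)=O` gives 1.9, a gap well beyond the scatter.

Compound 3 `CCOc1ccccc1-c1ccc(-c2nc3cnccc3c(N[C@H](CC)C(=O)N(C)C)c2C#N)cc1` keeps the whole of compound 1 and changes it in one place: (1-(dimethylcarbamoyl)propyl)amino in place of hydrogen on an aromatic carbon. A (1-(dimethylcarbamoyl)propyl)amino group takes the place of hydrogen on an aromatic carbon, ortho to a cyano group and opposite the ring nitrogen. The group brings one defined stereocentre and no net charge.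

Within the data shown here, no pair of measured compounds isolates this change, so the expectation rests on the structural change and the two values alone. Among the measured compounds shown here, the low number of compound 2, at 1.9, shows only that a compound in this set can sit far under compound 1. For the measured compounds named here, a small downward step in this assay is expected, of a size close to the scatter, and no step at all beyond the scatter remains possible. The estimated change is a number 0.30 log units lower from compound 1 to compound 3 (within the scatter). For compound 3 the expected value is 3.5, with an estimated range from 2.9 to 4.1.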

Compound 3, distribution coefficient: 3.7
Beside the measured number, compound 3's estimate is 0.20 log units below it, and the stated range covers the measured number.
By their numbers in this assay, from the lowest: compound 2; then compounds 3 and 1 (each within the scatter of the next).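

The first direct read on this position comes from compound 3: in this assay, (1-(dimethylcarbamoyl)propyl)amino in place of hydrogen on an aromatic carbon, ortho to a cyano group and opposite the ring nitrogen, gives a step of a number 0.10 log units lower from compound 1 to compound 3 (within the scatter). Before this result, no pair of compounds isolated any change at this position, and it now shows that an entering group of 9 heavy atoms, with 1 hydrogen-bond donor, 2 hydrogen-bond acceptors and 1 defined stereocentre, leaves the read-out of compound 3 indistinguishable from that of compound 1. Within the data shown here, nothing measured so far explains why so large a group produces a step of this size.

The compounds shown leave open whether a carboxylic acid, a primary amine or a longer alkyl chain on this same aromatic carbon would also stay within the scatter of compound 1. They also leave open whether the opposite configuration at the stereocentre, or a secondary amide in place of the dimethylamide, would give a step of similar size.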